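Compound 3: An Aryl Group Where Only Limits Exist

A few compounds are considered here, and "the series" means these few. Any claim that something is new, unique, unknown or untested is made for them only; others in the source may bear on it.

In a functional assay on HCT-116 cells (Homo sapiens) for antiproliferative activity, read by MTT assay, with a stated time of 72 h (a lower number here means a stronger inhibitor, a higher number a weaker inhibitor), compound 2 (`O=C1COc2ccc(-c3cnc(Cl)c(NS(=O)(=O)c4ccc(F)cc4)c3)cc2N1`) gives > 40000 nM, which is a limit and not a number. Within the data shown here, the only other measured compound, compound 1 (`COc1cccc(N2C(=O)COc3ccc(-c4cnc(Cl)c(NS(=O)(=O)c5ccc(F)cc5)c4)cc32)c1`), gives > 40000 nM, which is also a limit. The data therefore stand at the limit of > 40000 nM in this assay, at which 2 of the 2 values shown sit.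

Compound 3 (`Cc1ccc(N2C(=O)COc3ccc(-c4cnc(Cl)c(NS(=O)(=O)c5ccc(F)cc5)c4)cc32)cc1`) differs from compound 2 by one change: 4-methylphenyl in place of hydrogen on an amide-type nitrogen in a ring. The 4-methylphenyl group enters on the amide-type nitrogen in a ring, where compound 1 carries 3-methoxyphenyl. Among the measured compounds shown here, the one measured step that bears on this is a step that the two limits leave unreadable from compound 1 to compound 2, and it gives no size to carry over. With no readable step to suggest otherwise, no shift beyond the scatter is expected, and another limit is the likeliest result. The expected step is a number no higher from compound 2 to compound 3 (the limit leaves the size open). For compound 3 the estimated value is 40000 nM, with an expected range of 10000 nM to 80000 nM.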

Compound 3, half-maximal inhibitory concentration: 34300 nM
The estimate for compound 3 lay 1.2-fold (0.07 log units) above the measured number; measured number inside the range.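

In this assay, among these compounds, compound 3 gives the only one of the three values that is a number and not a limit, so an aryl group on the amide-type nitrogen in a ring now has a readable result. Adding the 4-methylphenyl group reads as an at least 1.1-fold lower number from compound 2 to compound 3 (0.06 log units; that floor lies within the scatter), and exchanging the aryl group reads as an at least 1.1-fold lower number from compound 1 to compound 3 (0.06 log units; that floor lies within the scatter). Going by these compounds, both steps are only floors within the scatter, so their true sizes stay open, and the series still sits mostly at the limit: the limit of > 40000 nM in this assay, at which 2 of the 3 values shown sit.

The compounds shown leave open whether a short alkyl chain such as ethyl, or a chain ending in a carboxylic acid, on this nitrogen would give a readable number. They also leave open how an amine on the phenyl ring would compare with the 4-methylphenyl group.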